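Methyl in Place of Hydrogen: Compound 1 to Compound 3

A few compounds are considered here, and "the series" means these few. Any claim that something is new, unique, unknown or untested is made for them only; others in the source may bear on it.

Measured so far in a functional assay, read by spectrophotometry, with a stated time of 15 min, tested at 20 ug/mL; a lower number here means a weaker effect, a higher number a stronger effect of the compound at the concentration tested:
compound 1 `Clc1ccc(/C=N/Nc2nc(-c3ccccc3)cs2)c(Cl)c1` gives 78.1%
compound 2 `COC(=O)c1cc(-c2csc(N/N=C/c3cccs3)n2)ccc1OCc1ccccc1` gives 79.6%

Of these two numbers, compound 1 holds the lower one, yet its nearest neighbour, compound 2, sits within the usual scatter of repeated measurements, so the two readings cannot be told apart. Among the measured compounds shown here, no step between measured compounds that differ in one place is known here, and the two measured compounds differ in several places at once.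

The unmeasured compound is compound 3 `Cc1ccc(-c2csc(N/N=C/c3ccc(Cl)cc3Cl)n2)cc1`. It differs from compound 1 by methyl in place of hydrogen on an aromatic carbon. For the measured compounds named here, with no measured step of this kind to draw on, the reading of compound 3 is expected to stay close to that of compound 1. In this assay the expected step is a number 0.1 percentage points lower from compound 1 to compound 3 (within the scatter), which is none beyond the scatter in either direction. Compound 3 is therefore estimated at 78%, with a range from 66% to 88%.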

Compound 3, a percentage reported as inhibition, at one concentration (the size of the read-out at that concentration, not a potency): 76.2%
Compound 3: the middle estimate sits 1.8 percentage points above what was measured; the range from low to high includes it.
By their numbers in this assay, from the lowest: compounds 3, 1 and 2 (each within the scatter of the next).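

Methyl in place of hydrogen on an aromatic carbon, para to a large group, is the first change at a single place to be read in this assay and it gives a number 1.9 percentage points lower from compound 1 to compound 3 (within the scatter) as its whole step. This position therefore carries a methyl with no reading that can be told apart from that of compound 1, so going from phenyl to 4-methylphenyl leaves the effect at the tested concentration intact. Nothing measured here bears on why this step is as it is.

The compounds shown leave open whether an amine, a carboxylic acid or a longer chain at this same place would give a step beyond the scatter. They also leave open whether a methyl on another carbon of this ring would read the same.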